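The source may report more compounds than this note shows. Statements on the series, on what has been measured and on what is new or still open speak of the compounds shown alone.

Measured in an ADME assay on microsomes from liver (Mus musculus) for metabolic stability, with a stated time of 10 min; on this read-out higher numbers stand for a more stable compound and lower numbers for a less stable compound:
- Compound 1 `O=C(O)[C@H]1CC[C@](F)(C(=O)N2CC[C@](c3ccc(C(F)(C(F)(F)F)C(F)(F)F)cc3)(S(=O)(=O)c3ccc(F)cc3)C2)CC1`: "not determined" (no result reported)
- Compound 2 `O=C(O)C1CCC(O)(C(=O)N2CC[C@](c3ccc(C(F)(C(F)(F)F)C(F)(F)F)cc3)(S(=O)(=O)c3ccc(F)cc3)C2)CC1`: 99%; 98% (2 entries)
- Compound 3 `NC(=O)[C@H]1CC[C@H](C(=O)N2CC[C@](c3ccc(C(F)(C(F)(F)F)C(F)(F)F)cc3)(S(=O)(=O)c3ccc(F)cc3)C2)CC1`: 100%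

In this small set, compound 3 stands at 100%, the only single number shown. Compound 1 has no result, and the record for its closest measured neighbour reads (the several entries of compound 2 in this assay, 99%; 98% (2 entries)). The values of compound 2 and compound 3 lie within the usual scatter of each other, so the two cannot be ranked, and both sit near the top of the read-out.

The next compound to be tested is compound 4 `O=C([C@H]1CC[C@H](CO)CC1)N1CC[C@](c2ccc(C(F)(C(F)(F)F)C(F)(F)F)cc2)(S(=O)(=O)c2ccc(F)cc2)C1`. It keeps the rest of compound 3 and alters a single group: hydroxymethyl in place of carbamoyl on a saturated ring carbon. Hydroxymethyl takes the place of carbamoyl on a saturated ring carbon, three ring bonds from the ring atom that bears a large group.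

Within the data shown here, no measured pair shows this change on its own, so its size in this assay has to be judged. With compound 3 at 100%, the read-out leaves almost no room for a rise, and any real movement could only be downward. The expected change is a number 7 percentage points lower from compound 3 to compound 4 (within the scatter), a small downward step that stays within the scatter. Compound 4 is estimated at 93%, with an expected range of 80% to 100%.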

Compound 4, percent of the compound remaining: 63%
The estimate for compound 4 lay 30 percentage points above the measured number; measured number outside the range, below it.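

In this assay, replacing carbamoyl with hydroxymethyl on a saturated ring carbon, three ring bonds from the ring atom that bears a large group, gives a number 37 percentage points lower from compound 3 to compound 4 (beyond the scatter). Among these compounds, this is the first step in the set that can be read at all, and it shows that the read-out at this ring carbon depends on which group sits there, even though both groups have the same counts of hydrogen-bond donors and acceptors and neither carries a net charge; the earlier compounds, which form no pair differing in one place, could not show this. Nothing in the record shown explains why this one change has so large a step.

On these data alone, it remains open whether the outcome follows from hydroxymethyl itself or from the loss of carbamoyl, since only these two groups have been compared at this place with the rest of the compound unchanged. An amine, a nitrile or a methoxymethyl group on the same ring carbon could show whether a number stays close to that of compound 3 or falls towards that of compound 4.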